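The compounds below may be only part of what the source reports. "The series", "measured", "known", "first", "only" and "open" are said of these compounds alone.

Working notes on the spiro-thiazoline series. Going by the values given here, compound 1 `Clc1ccc(NC2=NCCC3(CCCCC3)S2)cc1` gives 27.8 10^-6 cm/s in a physicochemical assay for permeability (a higher number here means that the compound crosses the layer faster, a lower number that the compound crosses the layer more slowly), the second highest of the three numbers so far. Among the compounds with values here, compound 2 `CCc1ccc(NC2=NCCC3(CCCCC3)S2)cc1` gives 41 10^-6 cm/s, and the step of a 1.5-fold higher number from compound 1 to compound 2 (0.17 log units; within the scatter) is the only one-place comparison in hand. Compound 3 `NC1=NCCC2(CCCCC2)S1`, which carries the shared core with no aryl at all, gives 7.33 10^-6 cm/s, beyond the scatter below compound 1.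

Compound 4 `Nc1ccc(NC2=NCCC3(CCCCC3)S2)cc1` differs from compound 1 as follows: amino in place of chloro on an aromatic carbon. Within the data shown here, no measured step covers an entering amino; the step from compound 1 to compound 2 swaps one group without a donor or acceptor for another and stays within the scatter, so it does not speak to a change that adds one hydrogen-bond donor and one acceptor. The value of compound 3 marks the lowest number in the set. Compound 4 is expected to fall below compound 1, a step of about a 2.8-fold lower number from compound 1 to compound 4 (0.44 log units; beyond the scatter), in this assay. The estimate for compound 4 is 10 10^-6 cm/s, with a range of 4 10^-6 cm/s to 24 10^-6 cm/s.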

Compound 4, apparent permeability: 2.04 10^-6 cm/s
For compound 4 the middle estimate is 4.9-fold (0.69 log units) above the measured one; the measured number lies below the stated range.
By their numbers in this assay, from the lowest: compound 4; then compound 3; then compounds 1 and 2 (each within the scatter of the next).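

In this assay this place on the aromatic ring, para to a large group, responds strongly to the group it carries: amino in place of chloro gives a 14-fold lower number from compound 1 to compound 4 (1.13 log units; beyond the scatter) and amino in place of ethyl gives a 20-fold lower number from compound 2 to compound 4 (1.30 log units; beyond the scatter) whereas ethyl in place of chloro gave only (a 1.5-fold higher number from compound 1 to compound 2 (0.17 log units; within the scatter)). The entering amino has 1 hydrogen-bond donor and 1 hydrogen-bond acceptor, while the chloro that leaves has neither, but a single change cannot separate the two counts. No measurement bearing on the cause of the large step is available.

Amino is the only such group shown at this place, so one compound does not establish a trend. From the compounds shown here alone, whether a hydroxyl, a methylamino or an acetamido group would follow amino remains open.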